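This account rests on a few compounds, and the source may have more. Where it says the series, first, only, none or still open, it means among the compounds named here.

Compound 2 `O=C(NO)c1ccc(CNCc2nc(-c3ccc(F)cc3)no2)cc1` carries, within the scatter, the lower of the two numbers recorded so far in an assay on isolated protein for inhibition of histone deacetylase 8 (Homo sapiens), read by fluorescence, with a stated time of 20 min; on this read-out higher numbers stand for weaker inhibition and lower numbers for stronger inhibition; in this assay compound 2 gives 230 nM. Within the data shown here, its neighbour compound 1 `O=C(NO)c1ccc(CNCc2nc(-c3ccc(Cl)cc3)no2)cc1` gives 350 nM in this assay, and the only measured step, a 1.5-fold lower number from compound 1 to compound 2 (0.18 log units; within the scatter), amounts to a fluoro in place of a chloro on an aromatic carbon. Compound 3 `O=C(NO)c1ccc(CNCc2nc(-c3cccs3)no2)cc1` departs from compound 2 by thiophen-2-yl in place of 4-fluorophenyl on an aromatic carbon. Among the measured compounds shown here, no measured step changes the aromatic group at this position, so the step from compound 1 to compound 2 bears on it only loosely, as a sign that small changes to this ring have so far stayed within the scatter. On that basis the number expected for compound 3 in this assay is 280 nM, with a range from 120 nM to 700 nM. The step this estimate implies, a 1.2-fold higher number from compound 2 to compound 3 (0.09 log units; within the scatter), is expected to stay within the scatter.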

Compound 3, half-maximal inhibitory concentration: 8260 nM
Beside the measured number, compound 3's estimate is 30-fold (1.47 log units) below it; measured number above the stated range.
By their numbers in this assay, from the lowest: compounds 2 and 1 (each within the scatter of the next); then compound 3.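

Thiophen-2-yl in place of 4-fluorophenyl brings a 36-fold higher number from compound 2 to compound 3 (1.56 log units; beyond the scatter) in this assay, and thiophen-2-yl in place of 4-chlorophenyl brings a 24-fold higher number from compound 1 to compound 3 (1.37 log units; beyond the scatter) on the same read-out. The earlier compounds shown here differed only in the halogen on the phenyl ring and stayed within the scatter, whereas these steps show that inhibition at this position depends strongly on the aromatic group itself, with compound 3 clearly the weakest of the three. The data offer no measurement that would explain this loss.

The change swaps a six-membered carbon ring for a five-membered ring holding sulfur and also removes the halogen, so the compounds shown cannot separate these differences. Unsubstituted phenyl, furan-2-yl or pyridin-2-yl on this carbon would bear on that question.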